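Methyl for isopropyl on the hydrazone carbon of compound 2

The source may report more compounds than this note shows. Statements on the series, on what has been measured and on what is new or still open speak of the compounds shown alone.

Three members of the series have numbers in a functional assay on HeLa cells (Homo sapiens) for antiproliferative activity, read by sulforhodamine B assay; on this read-out lower numbers stand for stronger inhibition and higher numbers for weaker inhibition. Compound 1 `C/C(=N\Nc1nc2ccccc2o1)c1cc(C)ncn1` gives 210 nM in this assay. Compound 2 `CC(C)/C(=N\Nc1nc2ccccc2o1)c1ccccn1` gives 185 nM, the lowest of the three numbers, though compound 1 sits within the scatter of it; compound 3 `C/C(=N\Nc1nc2ccccc2o1)c1ccc(C)nn1` gives 3390 nM, far beyond the scatter from compound 2. Compound 4 `C/C(=N\Nc1nc2ccccc2o1)c1ccccn1` has not yet been run in this assay. It differs from compound 2 by methyl in place of isopropyl on a carbon with a double bond to nitrogen. For the measured compounds named here, no measured pair shows this exchange alone; the only methyl-bearing analogue with a number, compound 1, gives 210 nM, close to compound 2. The step from compound 2 to compound 4 is therefore expected to be small, a 1.2-fold higher number from compound 2 to compound 4 (0.08 log units; within the scatter), with no direction beyond the scatter. Compound 4 is estimated at 220 nM, in the range 80 nM to 650 nM.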

Compound 4, half-maximal inhibitory concentration: 23 nM
Compound 4: middle estimate off by 9.6-fold (0.98 log units), on the high side; the measured number lies below the stated range.
By their numbers in this assay, from the lowest: compound 4; then compounds 2 and 1 (each within the scatter of the next); then compound 3.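

In this assay, the carbon with a double bond to nitrogen is sensitive to its substituent: methyl in place of isopropyl gives an 8.0-fold lower number from compound 2 to compound 4 (0.91 log units; beyond the scatter). For the compounds shown here, this is the first exchange that can be read at a single place, which the earlier compounds, differing from one another in more than one place, did not allow. Nothing available bears on the cause of this step.

Going by these compounds alone, with only two groups at this position, it remains open how hydrogen, ethyl or a longer chain would read here. Also open, as far as these compounds go, is whether the same exchange would carry over to the aromatic rings of compound 1 and compound 3.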